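This account rests on a few compounds, and the source may have more. Where it says the series, first, only, none or still open, it means among the compounds named here.

Compound 2, `CCOC(=O)c1cnc(N2CCN(Cc3ccc(F)cc3)CC2)nc1Oc1c(C)cc(-c2ccc(C#N)cc2)cc1C`, was examined in an ADME assay on MT4 cells (Homo sapiens) for cytotoxicity, read by MTT assay, with a stated time of 4 days; on this read-out lower numbers stand for higher toxicity in this test and higher numbers for lower toxicity in this test. In this assay compound 2 gives > 117000 nM, which is a limit of the assay rather than a number. The two further compounds stand in the same way. Compound 1, `CCOC(=O)c1cnc(N2CCN(Cc3cccc(C#N)c3)CC2)nc1Oc1c(C)cc(-c2ccc(C#N)cc2)cc1C`, gives in this assay > 125000 nM, again a limit. Compound 3, `CCOC(=O)c1cnc(N2CCN(Cc3ccc(C(=O)OC)cc3)CC2)nc1Oc1c(C)cc(-c2ccc(C#N)cc2)cc1C`, gives in this assay > 125000 nM, also a limit. The three measured steps, a step that the two limits leave unreadable from compound 1 to compound 2, a step that the two limits leave unreadable from compound 1 to compound 3 and a step that the two limits leave unreadable from compound 2 to compound 3, cannot be sized because every value sits at the limit of > 117000 nM in this assay, at which 1 of the 3 values shown sits, or at the limit of > 125000 nM in this assay, at which 2 of the 3 values shown sit.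

Compound 4, `CCOC(=O)c1cnc(N2CCN(Cc3ccc([N+](=O)[O-])cc3)CC2)nc1Oc1c(C)cc(-c2ccc(C#N)cc2)cc1C`, differs from compound 2 by nitro in place of fluoro on an aromatic carbon. For the measured compounds named here, no measured step gives a readable size for an exchange of this kind, so nothing among the three measured compounds points to a step in either direction. Compound 4 is therefore expected to stand at the limit as well, with an estimate of 125000 nM, ranging from 60000 nM to 250000 nM. The expected step that the limit leaves unreadable from compound 2 to compound 4 is thus none beyond the scatter.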

Compound 4, half-maximal cytotoxic concentration: > 125000 nM
Compound 4 was reported as a limit (the forecaster's own chance of this, stated with the estimate: 85%); the middle value sits exactly at the limit.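

In this assay compound 4 gives > 125000 nM, which is a limit and not a number. Its steps to compound 1, compound 2 and compound 3 therefore cannot be read. The compounds shown leave open at what concentration any of these four becomes toxic in this test, and whether the exchanged groups change that concentration at all.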